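Expected Oral Exposure of Compound 3

The compounds below may be only part of what the source reports. "The series", "measured", "known", "first", "only" and "open" are said of these compounds alone.

The record in an ADME assay on the whole organism (plasma, strain Sprague-Dawley) for pharmacokinetics, with Rattus norvegicus as the target, read by LC-MS, at a dose of 10 mg/kg by the oral route (on this read-out higher numbers stand for higher exposure at the dose given and lower numbers for lower exposure), is thin. Compound 1 (`CCN1CCC(Oc2ccnc(C(=O)Nc3ccc(NC(=O)Nc4cc(C(C)(C)C)on4)cc3)c2)CC1`) carries only the entry "not determined" (no result reported) and offers no number for comparison. Among the compounds with values here, compound 2 (`CC1(C)CC(Oc2ccc(C(=O)Nc3ccc(NC(=O)Nc4cc(C(C)(C)C)on4)cc3)nc2)CC(C)(C)N1`) gives 1280 ng.h/mL in this assay and is the only compound with a number, so it cannot yet be ranked against any other.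

Compound 3 (`CC(C)N1CCC(Oc2ccc(C(=O)Nc3ccc(NC(=O)Nc4cc(C(C)(C)C)on4)cc3)nc2)CC1`) has not yet been measured. It differs from compound 2 in one place, on an oxygen on an aromatic ring, where 1-isopropylpiperidin-4-yl stands in place of 2,2,6,6-tetramethylpiperidin-4-yl (1-isopropylpiperidin-4-yl in place of 2,2,6,6-tetramethylpiperidin-4-yl on an oxygen on an aromatic ring). Each group is a six-membered non-aromatic ring with 1 hetero atom. Within the data shown here, no step between measured compounds shows what such a change does, so the expectation rests on compound 2 at 1280 ng.h/mL alone and carries a wide range. The expected change in this assay is a 1.4-fold lower number from compound 2 to compound 3 (0.15 log units; within the scatter) and points slightly downward, no larger than the usual scatter of repeated measurements. Compound 3 is accordingly estimated at 900 ng.h/mL with 250 ng.h/mL to 3000 ng.h/mL as its expected range.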

Compound 3, area under the concentration-time curve: 1820 ng.h/mL
For compound 3 the middle estimate is 2.0-fold (0.31 log units) below the measured one, and the stated range covers the measured number.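

In this assay the change of 2,2,6,6-tetramethylpiperidin-4-yl to 1-isopropylpiperidin-4-yl on an oxygen on an aromatic ring reads as a 1.4-fold higher number from compound 2 to compound 3 (0.15 log units; within the scatter) and gives this position its first readable step. At this position the read-out therefore does not separate the two groups, although both are six-membered non-aromatic rings with 1 hetero atom and only the leaving group carries a hydrogen-bond donor. Nothing shown bears on what lies behind this result, so the step stands as an observation without an explanation.

The compounds shown leave open whether exposure would stay in the same range with a group of another kind on this oxygen, such as a plain piperidin-4-yl with a hydrogen on its nitrogen, a morpholine or a chain ending in a carboxylic acid. Within the data shown here, they also leave open whether the same exchange would give a similar step on another core, since this single pair is the only readable comparison and compound 1 adds no number to set beside it.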